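This account rests on a few compounds, and the source may have more. Where it says the series, first, only, none or still open, it means among the compounds named here.

In a functional assay on KB cells (Homo sapiens) for inhibition (on this read-out higher numbers stand for weaker inhibition and lower numbers for stronger inhibition), compound 1 (`Cc1ccc(Cn2c(N)nc3cc(Cl)c(Cl)cc32)cc1`) gives 50000 nM. Compound 2 (`Nc1nc2cc(Cl)c(Cl)cc2n1Cc1cccc(Cl)c1`) gives 65000 nM and compound 3 (`Cc1cccc(Cn2c(N)nc3cc(Cl)c(Cl)cc32)c1`) gives 65000 nM. All three sit within the usual scatter of one another, so compound 1 cannot be ranked against the other two. Compound 4 (`Nc1nc2cc(Cl)c(Cl)cc2n1Cc1ccc(F)cc1`) is still unmeasured. It differs from compound 1 by fluoro in place of methyl on an aromatic carbon, with fluoro in place of methyl on an aromatic carbon. Going by the values given here, the only measured swap of this kind is no change at the digits printed from compound 2 to compound 3 (within the scatter), which exchanged chloro and methyl and is a guide, not a direct match. On that evidence, no shift beyond the scatter is expected in this assay. The estimated change is a 1.1-fold higher number from compound 1 to compound 4 (0.04 log units; within the scatter). Compound 4 is expected at 55000 nM, within an estimated range of 25000 nM to 100000 nM.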

Compound 4, half-maximal inhibitory concentration: 70000 nM
Estimate against measurement, compound 4: 1.3-fold (0.10 log units) below; the measured number falls inside the stated range.
By their numbers in this assay, from the lowest: compounds 1, 2, 3 and 4 (each within the scatter of the next).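

In this assay, putting fluoro in place of methyl on an aromatic carbon, para to a large group, gives a 1.4-fold higher number from compound 1 to compound 4 (0.15 log units; within the scatter). At this position, then, the exchange of these two single-atom groups shifts the read-out by no more than the scatter, so the position shows no sensitivity to this particular change. Nothing measured here speaks to why the number holds. Still open, on these data alone, is whether an amine, a carboxylic acid or a longer chain such as butyl at this position would move the number beyond the scatter.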